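This account rests on a few compounds, and the source may have more. Where it says the series, first, only, none or still open, it means among the compounds named here.

Compound 1 `COc1ccc(Cn2nnc3c(C(N)=O)ncn3c2=O)cc1`: > 50000 nM
Compound 2 `COc1ccc(Cn2nnc3c(C(N)=O)ncn3c2=O)cc1OC`: > 50000 nM
Compound 3 `COc1cc(Cn2nnc3c(C(N)=O)ncn3c2=O)cc(OC)c1OC`: not yet measured

Both values come from a functional assay on SNB-19 cells (Homo sapiens) for inhibition, read by MTT assay, with a stated time of 7 days; a lower number here means a stronger inhibitor of growth, a higher number a weaker inhibitor of growth. Compound 1 gives > 50000 nM, which is a limit and not a number. Compound 2 gives > 50000 nM, which is also a limit. It therefore stands at the limit of > 50000 nM in this assay, at which 2 of the 2 values shown sit.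

Compound 3 differs from compound 2 by methoxy in place of hydrogen on an aromatic carbon. The same kind of exchange was measured once, as a step that the two limits leave unreadable from compound 1 to compound 2. That step gives no size to carry over, so no step beyond the scatter is expected in this assay. The expected step is a number no higher from compound 2 to compound 3 (the limit leaves the size open). Compound 3 is estimated at 50000 nM, with an expected range of 20000 nM to 100000 nM.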

Compound 3, concentration for 50% growth inhibition: > 50000 nM
Compound 3: only a limit was reported; the forecaster's own chance of this, stated with the estimate: 85%; the middle value sits exactly at the limit.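

In this assay, going by these compounds alone, compound 2 and compound 3 each give only a limit, so no step between them can be read. The compounds shown leave open how strongly any of them inhibits growth, and whether added methoxy groups change that.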